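The source may hold more compounds than are shown below. What is called first, only, known or untested is meant among the compounds shown, and "the series" means these compounds.

Three analogues built on one shared core have been examined in a functional assay on HepG2 cells (Homo sapiens) for antiproliferative activity, read by MTT assay; a lower number here means a stronger inhibitor, a higher number a weaker inhibitor. Compound 1 `O=C1N=C(N2CCC[C@H]2C(=O)Nc2ccc3ncnc(Nc4cccc(Cl)c4)c3c2)S/C1=C/c1cccc(Cl)c1`, which carries 3-chlorophenyl on a double-bonded chain carbon bound to a double-bonded ring carbon, gives 27600 nM. Compound 2 `O=C1N=C(N2CCC[C@H]2C(=O)Nc2ccc3ncnc(Nc4cccc(Cl)c4)c3c2)S/C1=C/c1cccnc1`, bearing pyridin-3-yl at that place, gives 8500 nM, and compound 3 `O=C1N=C(N2CCC[C@H]2C(=O)Nc2ccc3ncnc(Nc4cccc(Cl)c4)c3c2)S/C1=C/c1ccc(-c2ccccc2)cc1`, with 4-phenylphenyl there, gives 15400 nM. Among the three, compound 3 stands second highest; the steps of a 1.8-fold lower number from compound 1 to compound 3 (0.25 log units; within the scatter) and a 1.8-fold higher number from compound 2 to compound 3 (0.26 log units; within the scatter) both lie within the scatter, while only the step of a 3.2-fold lower number from compound 1 to compound 2 (0.51 log units; beyond the scatter) is beyond it.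

Compound 4 `O=C1N=C(N2CCC[C@H]2C(=O)Nc2ccc3ncnc(Nc4cccc(Cl)c4)c3c2)S/C1=C/c1cccc(Br)c1` has not yet been measured. It differs from compound 3 by 3-bromophenyl in place of 4-phenylphenyl on a double-bonded chain carbon bound to a double-bonded ring carbon. The measured step that bears most directly on this change is the one between 3-chlorophenyl and 4-phenylphenyl at the same place, which runs the opposite way to the present change and was small. Because a 1.8-fold lower number from compound 1 to compound 3 (0.25 log units; within the scatter) lay within the scatter, the change to compound 4 is expected to bring a 1.6-fold higher number from compound 3 to compound 4 (0.21 log units; within the scatter), a shift that would itself be within the scatter, leaning if anything toward a higher number. In this assay compound 4 is therefore estimated to give 25000 nM, with a range from 10000 nM to 60000 nM.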

Compound 4, half-maximal inhibitory concentration: 21300 nM
Beside the measured number, compound 4's estimate is 1.2-fold (0.07 log units) above it; the measured number falls inside the stated range.
By their numbers in this assay, from the lowest: compounds 2, 3, 4 and 1 (each within the scatter of the next, the first and the last beyond it).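

In this assay, bromo in place of chloro on an aromatic carbon gives a 1.3-fold lower number from compound 1 to compound 4 (0.11 log units; within the scatter), and 3-bromophenyl, with one aromatic ring of carbon only, in place of 4-phenylphenyl, with two, gives a 1.4-fold higher number from compound 3 to compound 4 (0.14 log units; within the scatter); both steps lie within the scatter, so neither exchange on the double-bonded chain carbon bound to a double-bonded ring carbon is resolved by this measurement. The step of a 2.5-fold higher number from compound 2 to compound 4 (0.40 log units; beyond the scatter) is modest but beyond the scatter, so pyridin-3-yl is now separated from both halogen-bearing phenyl groups, although compound 3 goes against any wider split between pyridin-3-yl and the carbon-only aromatic groups, as its step from compound 2 stays within the scatter. Nothing available here accounts for these differences.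

The compounds shown leave open whether the lower number seen with pyridin-3-yl extends to other nitrogen-containing rings, such as pyridin-4-yl or pyrimidin-5-yl. They also leave open where an unsubstituted phenyl, or a phenyl carrying a carboxylic acid or a dimethylamino group, would fall at this place.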